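The source may hold more compounds than are shown below. What is called first, only, known or untested is meant among the compounds shown, and "the series" means these compounds.

Measured compounds:
- compound 1 `O=C(O[C@H]1C[C@H](n2cc(F)c(=O)[nH]c2=O)O[C@@H]1COP(=O)(O)Oc1ccccc1)c1ccccc1`: 1270 nM
- compound 2 `CCCCCCCCCc1ccc(OP(=O)(O)OC[C@H]2O[C@@H](n3cc(F)c(=O)[nH]c3=O)C[C@@H]2OC(=O)c2ccccc2)cc1`: 39900 nM
- compound 3 `CCOC(=O)C[n+]1cccc2cc(OP(=O)([O-])OC[C@H]3O[C@@H](n4cc(F)c(=O)[nH]c4=O)C[C@@H]3OC(=O)c3ccccc3)ccc21`: 34900 nM

In a functional assay on MRC5 cells (Homo sapiens) for cytotoxicity, read by MTT assay, with a stated time of 48 h (on this read-out lower numbers stand for stronger inhibition and higher numbers for weaker inhibition), compound 1 gives the lowest of the three numbers, so it is the strongest inhibitor of cell growth among them. Compound 3 stands closest to it, and compound 2 furthest; both lie beyond the scatter.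

Compound 4 `C[N+]1(C)CCC(OP(=O)([O-])OC[C@H]2O[C@@H](n3cc(F)c(=O)[nH]c3=O)C[C@@H]2OC(=O)c2ccccc2)CC1` is not yet measured. It differs from compound 1 in one place: a group of 12 heavy atoms (7 carbon, 1 nitrogen, 3 oxygen, 1 phosphorus; one six-membered non-aromatic ring with 1 hetero atom) in place of a group of 10 heavy atoms (6 carbon, 3 oxygen, 1 phosphorus; one six-membered aromatic ring of carbon only), on an oxygen on a saturated carbon. The change thus swaps the phosphate partner at the end of the sugar chain for a ring bearing a nitrogen.

Going by the values given here, only one measured step touches this region of the molecule: a 31-fold higher number from compound 1 to compound 2 (1.50 log units; beyond the scatter). There, adding a nonyl chain to the aromatic ring on the phosphate made the number much higher, and compound 3, which also carries a different group on the same phosphate, gives 34900 nM, also far above compound 1. Both changes at this end of the molecule therefore weakened the effect in this assay. A similar outcome is expected here: compound 4 is estimated to show a 20-fold higher number from compound 1 to compound 4 (1.29 log units; beyond the scatter), a clearly higher number. The estimate for compound 4 is 25000 nM, with a range from 6000 nM to 80000 nM.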

Compound 4, half-maximal inhibitory concentration in the MRC5 assay: 8300 nM
Estimate against measurement, compound 4: 3.0-fold (0.48 log units) above; the measured number falls inside the stated range.
By their numbers in the MRC5 assay, from the lowest: compound 1; then compound 4; then compounds 3 and 2 (each within the scatter of the next).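

In the MRC5 assay the six-membered non-aromatic ring with 1 hetero atom, in place of the six-membered aromatic ring of carbon only, gives a 6.5-fold higher number from compound 1 to compound 4 (0.82 log units; beyond the scatter) as its step, so a change at this oxygen on a saturated carbon does not have to raise the number as far as the nonyl chain did (a 31-fold higher number from compound 1 to compound 2 (1.50 log units; beyond the scatter)). In a physicochemical assay for metabolic stability, read by HPLC, tested at 2 mM (a lower number here means that the compound disappears faster, a higher number that the compound lasts longer), the same change also goes with a much longer half-life: the measured half-life of compound 1, 6.6 h, and of compound 4, > 120 h, an at least 18-fold higher number (1.25 log units; beyond the scatter). In the physicochemical assay compound 1 gives 6.6 h. In the physicochemical assay compound 4 gives > 120 h as a limit of the assay and not as a number.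

Compound 4 alone carries this ring, so the compounds shown cannot tell which part of it matters. A ring bearing a carboxylic acid instead of the nitrogen, or a plain amine, would be one way to separate these parts.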